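The source may hold more compounds than are shown below. What is called first, only, known or untested is meant among the compounds shown, and "the series" means these compounds.

Measured so far:
compound 1 (`COc1ccccc1/C=C(\C(=O)c1ccc(Cl)cc1)S(=O)(=O)Cc1ccc(Cl)c(Cl)c1`) gives 1000 nM
compound 2 (`COc1ccccc1/C=C(\C(=O)c1ccc(Cl)cc1)S(=O)(=O)c1ccc(C)cc1`) gives 1000 nM
compound 3 (`COc1ccccc1/C=C(\C(=O)c1ccc(Cl)cc1)S(=O)(=O)c1ccc(Br)cc1`) gives 10000 nM

In a functional assay on DU-145 cells (Homo sapiens) for inhibition, read by trypan blue exclusion, with a stated time of 96 h (a higher number here means a weaker inhibitor of growth, a lower number a stronger inhibitor of growth), compound 2 stands level with compound 1, together the lowest of the three numbers, while compound 3 lies furthest from it.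

The next compound, compound 4 (`CC(=O)Oc1ccc(/C=C(\C(=O)c2ccc(Cl)cc2)S(=O)(=O)c2ccc(C)cc2)cc1`), departs from compound 2 at a place not yet varied in this set (4-acetoxyphenyl in place of 2-methoxyphenyl on a double-bonded chain carbon bound to a double-bonded chain carbon). It carries 4-acetoxyphenyl in place of 2-methoxyphenyl on a double-bonded chain carbon bound to a double-bonded chain carbon.

Going by the values given here, no measured step touches this place. All three steps change the group on the sulfonyl sulfur, so they serve only as a guide to how far numbers move in this series. The record is no change at the digits printed from compound 1 to compound 2 (within the scatter), then a 10-fold higher number from compound 1 to compound 3 (1.00 log units; beyond the scatter), and finally a 10-fold higher number from compound 2 to compound 3 (1.00 log units; beyond the scatter) as the step starting from compound 2.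

They give no direction for the new change, so only a small move toward a higher number in this assay is expected, short of the larger measured steps. The expected step is a 2.0-fold higher number from compound 2 to compound 4 (0.30 log units; within the scatter) at the middle of the estimate. For compound 4 the estimated value is 2000 nM with an expected range from 300 nM to 10000 nM in this read-out.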

Compound 4, concentration for 50% growth inhibition: 25000 nM
The estimate for compound 4 lay 13-fold (1.10 log units) below the measured number, and the stated range ends below it.
By their numbers in this assay, from the lowest: compounds 1 and 2 (each within the scatter of the next); then compound 3; then compound 4.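

The group on the double-bonded chain carbon bound to a double-bonded chain carbon now proves to matter in this assay: the first change read at this place gives a 25-fold higher number from compound 2 to compound 4 (1.40 log units; beyond the scatter) and counts as large, while the change on the sulfonyl sulfur starting from the same compound gives a 10-fold higher number from compound 2 to compound 3 (1.00 log units; beyond the scatter) and counts as modest. The number in this series therefore moves at a second place in the shared core, and with 4-methylphenyl held on the sulfonyl sulfur, 4-acetoxyphenyl in place of 2-methoxyphenyl gives a weaker inhibitor of growth. No measurement to hand accounts for the size of this step.

This single step alters both the substituent and where it sits on the aromatic ring, so the compounds shown do not separate the two, and a 4-methoxyphenyl or a 2-acetoxyphenyl group at this place would be needed to tell them apart. Also open, from the compounds shown here alone, are how a 4-hydroxyphenyl group would read here and whether the step keeps its size with 3,4-dichlorobenzyl or 4-bromophenyl on the sulfonyl sulfur.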